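A few compounds are considered here, and "the series" means these few. Any claim that something is new, unique, unknown or untested is made for them only; others in the source may bear on it.

Going by the values given here, in a functional assay on SGC-7901 cells (Homo sapiens) for inhibition, read by MTT assay, with a stated time of 24 h (on this read-out lower numbers stand for stronger inhibition and higher numbers for weaker inhibition), three compounds with a shared core have numbers so far. Compound 1 (`CC1(C)[C@H]2CC[C@]1(C)N(Cc1cn(-c3cccc(F)c3)nn1)C(=O)C2`) gives 530 nM, compound 2 (`CC1(C)[C@H]2CC[C@]1(C)N(Cc1cn(-c3ccccc3C#N)nn1)C(=O)C2`) gives 260 nM, and compound 3 (`CC1(C)[C@H]2CC[C@]1(C)N(Cc1cn(-c3ccc(Br)cc3)nn1)C(=O)C2`) gives 450 nM. Compound 3 cannot be told apart from either neighbour: the steps are a 1.2-fold lower number from compound 1 to compound 3 (0.07 log units; within the scatter) and a 1.7-fold higher number from compound 2 to compound 3 (0.24 log units; within the scatter). Only a 2.0-fold lower number from compound 1 to compound 2 (0.31 log units; beyond the scatter) passes the scatter, and modestly.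

Compound 4 (`CC1(C)[C@H]2CC[C@]1(C)N(Cc1cn(-c3ccccc3O)nn1)C(=O)C2`) has a 2-hydroxyphenyl in place of the 4-bromophenyl on an aromatic nitrogen (2-hydroxyphenyl in place of 4-bromophenyl on an aromatic nitrogen). All three measured steps bear on this change, since each swaps one phenyl group on that nitrogen for another. Among the compounds with values here, none of the measured compounds carries a hydroxyl group, so the direction is uncertain. The largest of these swaps, a 2.0-fold lower number from compound 1 to compound 2 (0.31 log units; beyond the scatter), is small, so only a small change is expected here, leaning slightly towards the lower numbers of compound 2. The expected step is a 1.2-fold lower number from compound 3 to compound 4 (0.07 log units; within the scatter), which amounts to no clear change. Compound 4 is estimated at 380 nM, with an expected range from 160 nM to 900 nM.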

Compound 4, half-maximal inhibitory concentration: 410 nM
For compound 4 the middle estimate is 1.1-fold (0.03 log units) below the measured one, within the range that was stated.
By their numbers in this assay, from the lowest: compounds 2, 4, 3 and 1 (each within the scatter of the next, the first and the last beyond it).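

In this assay the 2-hydroxyphenyl group, the first here with a hydrogen-bond donor in its count, cannot be told apart from the other groups on this aromatic nitrogen: a 1.1-fold lower number from compound 3 to compound 4 (0.04 log units; within the scatter) and a 1.3-fold lower number from compound 1 to compound 4 (0.11 log units; within the scatter) and a 1.6-fold higher number from compound 2 to compound 4 (0.20 log units; within the scatter) all lie within the scatter. Thus neither 2-hydroxyphenyl in place of 4-bromophenyl nor hydroxy in place of cyano gives a readable change, and compound 4 does not add a second clear difference to the single one between compound 1 and compound 2. No evidence is available on what lies behind these results.

Still open, as far as these compounds go, is whether an amine or a carboxylic acid on the phenyl ring would take the number beyond the scatter. A longer chain in place of the phenyl ring on this nitrogen also remains untested in the compounds shown here.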